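The compounds below may be only part of what the source reports. "The series", "measured", "known", "first", "only" and "open" are said of these compounds alone.

Among the compounds with values here, in a functional assay on HL-60 cells (Homo sapiens) for antiproliferative activity, read by MTT assay (a lower number here means a stronger inhibitor, a higher number a weaker inhibitor), compound 1 `C=CC[C@@H]1O[C@H](COCc2ccccc2)[C@@H](OCc2ccccc2)[C@H](OCc2ccccc2)[C@H]1O` gives 15100 nM, the only number in this small series. Compound 2 `O[C@@H]1[C@@H](OCc2ccccc2)[C@H](OCc2ccccc2)[C@@H](COCc2ccccc2)O[C@H]1CC1CC1` is reported as "not active" (no number reported). Compound 3 `CCCC[C@@H]1O[C@H](COCc2ccccc2)[C@@H](OCc2ccccc2)[C@H](OCc2ccccc2)[C@H]1O` is likewise reported as "not active" (no number reported), so it stands with no single number and cannot be ranked by value. Compound 4 `CC[C@@H]1O[C@H](COCc2ccccc2)[C@@H](OCc2ccccc2)[C@H](OCc2ccccc2)[C@H]1O` has not yet been measured. The structural change is hydrogen in place of ethyl on a saturated chain carbon, two bonds along the chain from a saturated ring carbon, with hydrogen in place of ethyl on a saturated chain carbon, two bonds along the chain from a saturated ring carbon, so butyl becomes ethyl. A modest step toward stronger inhibition is expected, leaving compound 4 weaker than compound 1 at 15100 nM, though no reported number may result. For compound 4 the expected value is about 25000 nM, with an estimated range of 10000 nM to 60000 nM.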

Compound 4, half-maximal inhibitory concentration: 8200 nM
Estimate against measurement, compound 4: 3.0-fold (0.48 log units) above, and the stated range ends above it.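

In this assay compound 4, with ethyl, gives 8200 nM where compound 3, with butyl, is reported as not active, so the chain at this position can separate a measurable number from none, though this step cannot be read as a size. Methyl in place of vinyl on a saturated chain carbon bound to a saturated ring carbon gives a 1.8-fold lower number from compound 1 to compound 4 (0.27 log units; within the scatter) and leaves compound 1 and compound 4 indistinguishable here. Nothing shown explains these results. Going by these compounds, whether a propyl chain would keep a measurable number remains open. So does the effect of an amine or a carboxylic acid at this position.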